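This account rests on a few compounds, and the source may have more. Where it says the series, first, only, none or still open, it means among the compounds named here.

Measured compounds in a functional assay on CHO cells for agonist activity at 5-hydroxytryptamine receptor 4 (Homo sapiens), read by a luciferase reporter and cAMP accumulation, with a stated time of 4 h; a lower number here means that less compound is needed, a higher number that more compound is needed for the effect:

compound 1, `CC(C)c1nc(C(=O)NCC2(O)CCN(CC3CCOCC3)CC2)c2ccccn12`, 56.7 nM
compound 2, `CC(C)c1nc(C(=O)NCC2(C)CCN(CC3CCOCC3)CC2)c2ccccn12`, 53 nM
compound 3, `COCCCN1CC2C(C1)C2NC(=O)c1nc(C(C)C)n2ccccc12`, > 10000 nM

The only complete step among these is a 1.1-fold lower number from compound 1 to compound 2 (0.03 log units; within the scatter). Among the measured compounds shown here, for compound 3 the result in this assay is > 10000 nM, a limit of the assay rather than a number, and it is the one compound among the three that sits at the limit of > 10000 nM in this assay, at which 1 of the 3 values shown sits. So compound 3 stands at the weak end of what has been measured.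

Compound 4, `CC(C)c1nc(C(=O)NC2C3CN(CC(C)(C)O)CC32)c2ccccn12`, keeps the shared core and the bicyclic amine of compound 3 and changes only the group on the amine nitrogen: 1-hydroxy-1-methylethyl in place of 2-methoxyethyl on a saturated chain carbon bound to an amine nitrogen in a ring. For the measured compounds named here, no measured step covers this kind of change; the step from compound 1 to compound 2 swaps hydroxy for methyl on a ring carbon and is within the scatter, which gives little guidance here. With compound 3 at the limit, compound 4 is expected to stay weak, with the step of an at least 1.2-fold lower number from compound 3 to compound 4 (0.09 log units; that floor lies within the scatter). The estimate for compound 4 in this assay is 8000 nM, within a range from 1000 nM to 40000 nM.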

Compound 4, half-maximal effective concentration: > 10000 nM
Compound 4: no number, only a limit; the forecaster's own chance of this, stated with the estimate: 60%; middle value at least 1.2-fold (0.09 log units) away from the limit.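

In this assay compound 4 gives > 10000 nM, a limit of the assay and not a number. Among the compounds shown here, compound 3 also stands at a limit, so no step between compound 3 and compound 4 can be read. The compounds shown leave open whether 1-hydroxy-1-methylethyl in place of 2-methoxyethyl changes the activity at all.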